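Removing the carbamoylcyclohexyl group on two related cores

The source may report more compounds than this note shows. Statements on the series, on what has been measured and on what is new or still open speak of the compounds shown alone.

Compound 1 `CN(C)[C@H]1CC[C@H](Nc2ncnc3[nH]cc([C@H]4CC[C@H](C(N)=O)CC4)c23)CC1` is measured in a physicochemical assay for lipophilicity, using the shake flask method, at pH 7.4 (on this read-out lower numbers stand for lower lipophilicity and higher numbers for higher lipophilicity), at 0. Compound 2 `CN(C)[C@H]1CC[C@H](Nc2ncnc3[nH]ccc23)CC1` differs from it in one place, (hydrogen in place of 4-carbamoylcyclohexyl on an aromatic carbon), and in this assay compound 2 gives -0.6. The step is a number 0.60 log units lower from compound 1 to compound 2 (beyond the scatter). Compound 3 `CN(C)[C@H]1CC[C@H](Nc2ncnn3ccc([C@H]4CC[C@H](C(N)=O)CC4)c23)CC1` carries the same 4-carbamoylcyclohexyl group on a different core; the difference between the two cores is not broken down here. In this assay compound 3 gives 0.2, which lies within the scatter of compound 1 and beyond the scatter from compound 2. Compound 4 `CN(C)[C@H]1CC[C@H](Nc2ncnn3cccc23)CC1` is not yet measured; it stands to compound 3 as compound 2 stands to compound 1, with hydrogen in place of 4-carbamoylcyclohexyl on an aromatic carbon at the same place, so it is the same change, occurring twice among these compounds. The step from compound 3 to compound 4 is expected to be a number 0.60 log units lower from compound 3 to compound 4 (beyond the scatter), resting on one precedent only, because the same change gave a number 0.60 log units lower from compound 1 to compound 2 (beyond the scatter). For compound 4 in this assay the expected value is -0.4, with a likely range from -0.8 to 0.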

Compound 4, distribution coefficient: 0
Beside the measured number, compound 4's estimate is 0.40 log units below it, and the stated range covers the measured number.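

Replacing 4-carbamoylcyclohexyl with hydrogen gives a number 0.20 log units lower from compound 3 to compound 4 (within the scatter) in this assay, against a number 0.60 log units lower from compound 1 to compound 2 (beyond the scatter) for the same change on the other core. The step seen on the first core therefore did not carry over at the same size: it lies beyond the scatter on one core and within it on the other, so a step read on one of these cores is a weak guide to the other. This rests on two matched pairs and shows nothing about further cores, and nothing given here bears on what lies behind the contrast.

The compounds shown leave open whether other groups at this place on the five-membered aromatic ring, such as methyl or a cyclohexyl carrying a carboxylic acid in place of the carbamoyl, would also give steps that part between the two cores. Going by these compounds, it also remains open whether a longer chain there would follow either pair.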